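This account rests on a few compounds, and the source may have more. Where it says the series, first, only, none or still open, it means among the compounds named here.

The measured compounds are compound 1 `CCCn1c(=O)n(CC(=O)O)c(=O)c2[nH]cnc21`, compound 2 `CCCn1c(=O)n(CCC(N)=O)c(=O)c2[nH]cnc21` and compound 3 `CCCn1c(=O)n(CCOC)c(=O)c2[nH]cnc21`. In an assay on Cerebral cortex for binding affinity to adenosine receptor A1 (Cavia porcellus), read by radioligand binding (on this read-out higher numbers stand for weaker inhibition and lower numbers for stronger inhibition), compound 1 gives only a limit, > 200000 nM. Compound 2 gives 31500 nM and compound 3 gives 2500 nM. Of the two plain numbers, compound 2 stands highest; the step to the nearest one is a 13-fold lower number from compound 2 to compound 3 (1.10 log units; beyond the scatter), beyond the scatter. Compound 4 `CCCn1c(=O)n(CCOCC)c(=O)c2[nH]cnc21` is not yet measured; it differs from compound 2 by ethoxy in place of carbamoyl on a saturated chain carbon, two bonds along the chain from an aromatic nitrogen. That measured step, in which methoxy replaced the same carbamoyl, is the one that bears on this change, and a step of similar size and direction is therefore expected, a 16-fold lower number from compound 2 to compound 4 (1.20 log units; beyond the scatter). Compound 4 is thus estimated at 2000 nM, within 600 nM to 7000 nM.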

Compound 4, inhibition constant: 1900 nM
The estimate for compound 4 lay 1.1-fold (0.02 log units) above the measured number; low and high end bracket the measured number.
By their numbers in this assay, from the lowest: compounds 4 and 3 (each within the scatter of the next); then compound 2. At a limit, above all of these: compound 1.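

Swapping the end of the ether chain makes no readable difference: a methyl added to the methoxy of compound 3 leaves the number within the scatter (a 1.3-fold lower number from compound 3 to compound 4 (0.12 log units; within the scatter)). The advantage over the carbamoyl group therefore holds for ethoxy as well as methoxy (a 17-fold lower number from compound 2 to compound 4 (1.22 log units; beyond the scatter)). Compound 1 gives only a limit, so its step to the ethoxy compound is a bound rather than an exact size (an at least 100-fold lower number from compound 1 to compound 4 (2.02 log units; beyond the scatter)).

Nothing shown gives a cause for these steps.
On these data alone, whether an amine or a longer ether chain at this position would give a lower number remains open.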